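Chloro in Place of Fluoro on Compound 1

The compounds below may be only part of what the source reports. "The series", "measured", "known", "first", "only" and "open" are said of these compounds alone.

Compound 1 `CCOC(=O)C1=Cc2ccccc2OC1(OCc1cn(CC(=O)Nc2cccc(F)c2)nn1)C(F)(F)F` carries a (3-fluorophenyl)carbamoyl group on the shared core. In a functional assay on MCF7 cells (Homo sapiens) for inhibition, read by MTT assay, with a stated time of 24 h (on this read-out higher numbers stand for weaker inhibition and lower numbers for stronger inhibition), compound 1 gives only a limit, > 150000 nM, so no number is known for it. Compound 1 thus sits at the limit of > 150000 nM in this assay, at which 1 of the 3 values shown sits. Two other members of the set carry a different ring on the core: compound 2 `CCOC(=O)C1=Cc2ccccc2OC1(OCc1cc(-c2cccc(C(F)(F)F)c2)no1)C(F)(F)F` gives 22100 nM in this assay, and compound 3 `CCOC(=O)C1=Cc2ccccc2OC1(OCc1cc(-c2ccc(Cl)cc2)no1)C(F)(F)F` gives 18200 nM. For the measured compounds named here, the single measured step, a 1.2-fold lower number from compound 2 to compound 3 (0.08 log units; within the scatter), is the only comparison of one aromatic substituent against another in this set.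

Compound 4 `CCOC(=O)C1=Cc2ccccc2OC1(OCc1cn(CC(=O)Nc2cccc(Cl)c2)nn1)C(F)(F)F` differs from compound 1 by chloro in place of fluoro on an aromatic carbon, that is, (3-fluorophenyl)carbamoyl to (3-chlorophenyl)carbamoyl. The step from compound 2 to compound 3 changes a different substituent on a different ring and stayed within the scatter; it bears on compound 4 only loosely. Going by the values given here, nothing among the measured compounds points to a step beyond the scatter for this exchange. Compound 4 is therefore expected to remain at or near the limit, with an estimated step that the limit leaves unreadable from compound 1 to compound 4. The estimate for compound 4 is 200000 nM, expected to lie between 60000 nM and 600000 nM.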

Compound 4, half-maximal inhibitory concentration: 11600 nM
Beside the measured number, compound 4's estimate is 17-fold (1.24 log units) above it; measured number below the stated range.
By their numbers in this assay, from the lowest: compounds 4, 3 and 2 (each within the scatter of the next). At a limit, above all of these: compound 1.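

In this assay the exchange of fluoro for chloro on an aromatic carbon, meta to a large group, gives an at least 12-fold lower number from compound 1 to compound 4 (1.11 log units; beyond the scatter) and so shows that the number at this position can move beyond the scatter with a change of halogen alone, while no ring, hydrogen-bond donor, hydrogen-bond acceptor or net charge is altered. The only earlier step, a 1.2-fold lower number from compound 2 to compound 3 (0.08 log units; within the scatter), concerned another substituent on another ring, so the earlier compounds had shown no substituent exchange that moved the number beyond the scatter. Compound 1 stands at a limit and not at a number, so the step from it is a lower bound and its true size cannot be read: the limit of > 150000 nM in this assay, at which 1 of the 4 values shown sits.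

The compounds shown leave open whether this drop belongs to chloro in particular or would also come with bromo, methyl or methoxy on the same carbon of the 3-chlorophenyl ring. They also leave open whether the same exchange of fluoro for chloro would move the number on the ring carried by compound 2 and compound 3, where no such pair is shown.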